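Swapping Chlorine for Fluorine on a Benzamide Antagonist

The compounds below may be only part of what the source reports. "The series", "measured", "known", "first", "only" and "open" are said of these compounds alone.

Of the compounds shown here, three built on a shared core have been tested in a functional assay on HEK293 cells for antagonist activity at melanin-concentrating hormone receptor 1 (Homo sapiens), read by FLIPR and calcium flux; a higher number here means a weaker inhibitor, a lower number a stronger inhibitor. Compound 1, `CCN(C)c1nc(N[C@H]2CC[C@@H](NC(=O)c3ccc(F)c(F)c3)CC2)ncc1C`, gives 46 nM, and compound 2, `CNc1nc(N[C@H]2CC[C@@H](CNC(=O)c3cc(C(F)(F)F)cc(C(F)(F)F)c3)CC2)ncc1C`, gives 200 nM. Compound 3, `Cc1cc(N(C)C)nc(N[C@H]2CC[C@@H](NC(=O)c3ccc(Cl)cc3)CC2)n1`, gives 16 nM, the lowest of the three numbers, standing beyond the scatter from both compound 1 and compound 2. Compound 4, `Cc1cc(N(C)C)nc(N[C@H]2CC[C@@H](NC(=O)c3ccc(F)cc3)CC2)n1`, has not yet been measured. It differs from compound 3 by fluoro in place of chloro on an aromatic carbon. Going by the values given here, no measured pair shows this exact swap, so the expected step in this assay is small, most likely a modest weakening or none beyond the scatter: a 1.9-fold higher number from compound 3 to compound 4 (0.27 log units; within the scatter). Compound 4 is therefore estimated at 30 nM, in a range from 12 nM to 80 nM.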

Compound 4, half-maximal inhibitory concentration: 25 nM
Estimate against measurement, compound 4: 1.2-fold (0.08 log units) above; the range from low to high includes it.
By their numbers in this assay, from the lowest: compounds 3, 4 and 1 (each within the scatter of the next, the first and the last beyond it); then compound 2.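

Going by these compounds alone, compounds 3 and 4 form the only pair here that differs in a single place, so they give the first direct reading of this position. In this assay, fluoro in place of chloro on the aromatic carbon para to a large group gives a 1.6-fold higher number from compound 3 to compound 4 (0.19 log units; within the scatter), so the two halogens cannot be told apart at this site. Nothing measured here speaks to what lies behind this result.

Only these two halogens are compared at this position. Going by these compounds, whether a methoxy group, a nitrile or an amine there would fall in the same range remains open.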